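This account rests on a few compounds, and the source may have more. Where it says the series, first, only, none or still open, it means among the compounds named here.

Of the compounds shown here, three that share one core have been measured in a physicochemical assay for solubility, in phosphate buffer, with a stated time of 24 h, at pH 7.4, tested at 100 uM; a lower number here means a less soluble compound, a higher number a more soluble compound. Compound 1 `O=C(NCc1ccc(S(=O)(=O)c2cncc(C(F)(F)F)c2)cc1)N1Cc2ccncc2C1` gives 83000 nM. Compound 2 `O=C(NCc1ccc(S(=O)(=O)c2cc(F)cc(F)c2)cc1)N1Cc2ccncc2C1` gives 16000 nM, the lowest of the three numbers. Compound 3 `CC(C)n1cc(S(=O)(=O)c2ccc(CNC(=O)N3Cc4ccncc4C3)cc2)cn1` gives 192000 nM. The step of a 5.2-fold lower number from compound 1 to compound 2 (0.71 log units; beyond the scatter) and the step of a 12-fold higher number from compound 2 to compound 3 (1.08 log units; beyond the scatter) frame where compound 2 stands, while the step of a 2.3-fold higher number from compound 1 to compound 3 (0.36 log units; beyond the scatter) is the smaller one. Compound 4 `O=C(NCc1ccc(S(=O)(=O)N2CCC(O)CC2)cc1)N1Cc2ccncc2C1` has not yet been measured; it differs from compound 2 by 4-hydroxypiperidin-1-yl in place of 3,5-difluorophenyl on a sulfonyl sulfur. Within the data shown here, the measured exchanges on the sulfonyl sulfur each moved the number by a modest or large amount, and here the entering group is the first non-aromatic one. A rise beyond the scatter is therefore expected, a 9.4-fold higher number from compound 2 to compound 4 (0.97 log units; beyond the scatter). Compound 4 is thus estimated at 150000 nM, with a range from 60000 nM to 300000 nM.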

Compound 4, solubility: 174000 nM
Estimate against measurement, compound 4: 1.2-fold (0.06 log units) below; the range from low to high includes it.
By their numbers in this assay, from the lowest: compound 2; then compound 1; then compounds 4 and 3 (each within the scatter of the next).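

In this assay the sulfonyl sulfur tolerates a non-aromatic group without loss against the best aromatic one: a 1.1-fold lower number from compound 3 to compound 4 (0.04 log units; within the scatter), while an 11-fold higher number from compound 2 to compound 4 (1.04 log units; beyond the scatter) and a 2.1-fold higher number from compound 1 to compound 4 (0.32 log units; beyond the scatter). So an aromatic ring at this place is not required for numbers of this height among the compounds shown. Nothing measured here accounts for these steps. Open, from the compounds shown here alone, is whether the hydroxyl or the saturated ring carries the step from the 3,5-difluorophenyl compound. A plain piperidine or a morpholine on the sulfonyl sulfur would separate the two.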